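Replacing the piperazine chain with the dihydroxypropyl triazole

A few compounds are considered here, and "the series" means these few. Any claim that something is new, unique, unknown or untested is made for them only; others in the source may bear on it.

In a functional assay on A549 cells (Homo sapiens) for cytotoxicity, read by MTT assay, with a stated time of 72 h (a lower number here means a stronger inhibitor, a higher number a weaker inhibitor), compound 3 (`CN1CCN(CCCCCCn2c3c(c4ccccc42)C(=O)c2c[n+]([O-])c4ccccc4c2C3=O)CC1`) gives 330 nM and stands second highest of three numbers. Compound 2 (`CN1CCN(CCCCn2c3c(c4ccccc42)C(=O)c2c[n+]([O-])c4ccccc4c2C3=O)CC1`) gives 90 nM and compound 1 (`O=C1c2c[n+]([O-])c3ccccc3c2C(=O)c2c1c1ccccc1n2Cc1cn(CC(O)CO)nn1`) gives 880 nM as the highest number. Compound 4 (`O=C1c2c[n+]([O-])c3ccccc3c2C(=O)c2c1c1ccccc1n2Cc1cn(C[C@@H](O)CO)nn1`) is still unmeasured. Moving to it from compound 3 places 1-(2,3-dihydroxypropyl)-1H-1,2,3-triazol-4-yl in place of 5-(4-methylpiperazin-1-yl)pentyl on a saturated chain carbon bound to an aromatic nitrogen. Compound 1 carries the same triazole group, so the most relevant measurement is a 2.7-fold lower number from compound 1 to compound 3 (0.43 log units; beyond the scatter), a modest step that runs the opposite way here. The steps of a 9.8-fold lower number from compound 1 to compound 2 (0.99 log units; beyond the scatter) and a 3.7-fold higher number from compound 2 to compound 3 (0.56 log units; beyond the scatter) bear less directly, since both involve the piperazine chains. No measurement here shows what the defined stereocentre of compound 4 contributes. A modest rise is therefore expected, with the estimate being a 2.6-fold higher number from compound 3 to compound 4 (0.41 log units; beyond the scatter) in this assay. Compound 4 is estimated at 850 nM with a range of 450 nM to 1600 nM expected.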

Compound 4, half-maximal inhibitory concentration: 390 nM
Beside the measured number, compound 4's estimate is 2.2-fold (0.34 log units) above it; the whole stated range lies above it.
By their numbers in this assay, from the lowest: compound 2; then compounds 3 and 4 (each within the scatter of the next); then compound 1.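

In this assay, once its configuration is defined, 1-(2,3-dihydroxypropyl)-1H-1,2,3-triazol-4-yl cannot be told apart from 5-(4-methylpiperazin-1-yl)pentyl on the saturated chain carbon bound to an aromatic nitrogen, with a 1.2-fold higher number from compound 3 to compound 4 (0.07 log units; within the scatter). The 3-(4-methylpiperazin-1-yl)propyl chain of compound 2 remains clearly apart, with a 4.3-fold higher number from compound 2 to compound 4 (0.64 log units; beyond the scatter). Same atoms and bonds therefore do not guarantee the same number, as there is a 2.3-fold lower number from compound 1 to compound 4 (0.35 log units; beyond the scatter), and the only difference lies at the stereocentre: the fact that one of compounds 1 and 4 is drawn with a defined configuration and the other without, at the place where they differ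

The compounds shown leave open what the S configuration at that stereocentre would give, and so how much of this gap the configuration itself accounts for. Also open, going by these compounds, is how a carboxylic acid or a primary amine in place of the 2,3-dihydroxypropyl group would read in this assay.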